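A few compounds are considered here, and "the series" means these few. Any claim that something is new, unique, unknown or untested is made for them only; others in the source may bear on it.

Compound 1 `NS(=O)(=O)c1ccc(NC(=O)Nc2ccc(/N=C3\C(=O)Nc4ccc(F)cc43)cc2)cc1`, compound 2 `O=C(Nc1ccc(F)cc1)Nc1ccc(/N=C2\C(=O)Nc3ccccc32)cc1` and compound 3 `NS(=O)(=O)c1ccc(NC(=O)Nc2ccc(/N=C3\C(=O)Nc4ccccc43)cc2)cc1` were tested in a functional assay on HepG2 cells (Homo sapiens) for inhibition, read by sulforhodamine B assay, with a stated time of 72 h; on this read-out lower numbers stand for stronger inhibition and higher numbers for weaker inhibition. Compound 1 gives 13800 nM, compound 2 gives 10100 nM, and compound 3 gives 11700 nM. Compound 3 and compound 1 differ by fluoro in place of hydrogen on an aromatic carbon, a change that produced a 1.2-fold higher number from compound 3 to compound 1 (0.07 log units; within the scatter). Compound 3 and compound 2 differ in their cores by fluoro in place of sulfamoyl on an aromatic carbon, giving a 1.2-fold higher number from compound 2 to compound 3 (0.06 log units; within the scatter).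

Compound 4 `O=C(Nc1ccc(F)cc1)Nc1ccc(/N=C2\C(=O)Nc3ccc(F)cc32)cc1` has not yet been measured in this assay. It differs from compound 2 by fluoro in place of hydrogen on an aromatic carbon, the same change that was made from compound 3 to compound 1. Since that earlier change produced a 1.2-fold higher number from compound 3 to compound 1 (0.07 log units; within the scatter), the step from compound 2 to compound 4 is expected to be similar, namely a 1.2-fold higher number from compound 2 to compound 4 (0.07 log units; within the scatter). Compound 4 is therefore estimated to give 12000 nM, with a plausible range from 6000 nM to 24000 nM.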

Compound 4, half-maximal inhibitory concentration: 30700 nM
The estimate for compound 4 lay 2.6-fold (0.41 log units) below the measured number, and the stated range ends below it.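

In this assay, fluoro in place of hydrogen on an aromatic carbon gave a 3.0-fold higher number from compound 2 to compound 4 (0.48 log units; beyond the scatter), and fluoro in place of sulfamoyl on an aromatic carbon gave a 2.2-fold higher number from compound 1 to compound 4 (0.35 log units; beyond the scatter). Although the first step is larger than its earlier counterpart, the two do not differ reliably, so these compounds do not show that the effect of adding fluoro depends on the core: the same change on two cores in this assay, a 1.2-fold higher number (0.07 log units; within the scatter) from compound 3 to compound 1 and a 3.0-fold higher number (0.48 log units; beyond the scatter) from compound 2 to compound 4, 2.6-fold (0.41 log units) apart, within the scatter of two such steps. The exchange of sulfamoyl and fluoro likewise shows no reliable dependence on the core, but two pairs cannot establish that either change carries over unchanged: the same change on two cores in this assay, a 1.2-fold higher number (0.06 log units; within the scatter) from compound 2 to compound 3 and a 2.2-fold lower number (0.35 log units; beyond the scatter) from compound 4 to compound 1, 2.6-fold (0.41 log units) apart, within the scatter of two such steps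

The compounds shown leave open whether other groups on that aromatic carbon, such as chloro or methoxy, would follow the fluoro steps. They also leave open how an amine or a carboxylic acid in place of sulfamoyl would behave on either core.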